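Halogen series on the aryl ring, then a hydroxy

A few compounds are considered here, and "the series" means these few. Any claim that something is new, unique, unknown or untested is made for them only; others in the source may bear on it.

Three measured compounds share one core and differ in a single group on the aromatic ring. Compound 1 `O=C(CSc1nnc(-c2ccncc2)o1)N/N=C/c1ccc(F)cc1` gives 17800 nM in a functional assay on BGC-823 cells (Homo sapiens) for cytotoxicity, read by MTT assay, with a stated time of 48 h; a higher number here means a weaker inhibitor, a lower number a stronger inhibitor. Compound 2 `O=C(CSc1nnc(-c2ccncc2)o1)N/N=C/c1ccc(Cl)cc1` gives 20500 nM in this assay. Compound 3 `O=C(CSc1nnc(-c2ccncc2)o1)N/N=C/c1ccc(Br)cc1` gives 24500 nM in this assay, the highest of the three numbers, yet a 1.4-fold higher number from compound 1 to compound 3 (0.14 log units; within the scatter) and a 1.2-fold higher number from compound 2 to compound 3 (0.08 log units; within the scatter) both sit within the scatter, as does a 1.2-fold higher number from compound 1 to compound 2 (0.06 log units; within the scatter). On these numbers the three compounds cannot be told apart.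

Compound 4 `O=C(CSc1nnc(-c2ccncc2)o1)N/N=C/c1ccc(O)cc1` is the next member, carrying (hydroxy in place of bromo on an aromatic carbon). The measured steps that bear on it are the halogen exchanges at the same position, and all three stayed within the scatter. Within the data shown here, no measured step exchanges a halogen for a hydroxy, so the bearing of those steps on this change is indirect. The expectation is therefore no step beyond the scatter in this assay, in no particular direction, with a wider range to reflect the untested group. Compound 4 is expected to give about 25000 nM in this assay, between 8000 nM and 70000 nM. This expected step is a 1.0-fold higher number from compound 3 to compound 4 (0.01 log units; within the scatter).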

Compound 4, half-maximal inhibitory concentration: 7940 nM
Estimate against measurement, compound 4: 3.1-fold (0.50 log units) above; the whole stated range lies above it.
By their numbers in this assay, from the lowest: compound 4; then compounds 1, 2 and 3 (each within the scatter of the next).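

In this assay this position proves able to move the number after all: where the halogen exchanges stayed within the scatter, the change from halogen to hydroxy gives a 3.1-fold lower number from compound 3 to compound 4 (0.49 log units; beyond the scatter) as well as a 2.6-fold lower number from compound 2 to compound 4 (0.41 log units; beyond the scatter) and a 2.2-fold lower number from compound 1 to compound 4 (0.35 log units; beyond the scatter) with all three steps beyond the scatter. Compound 4 therefore stands apart as the strongest inhibitor of the four, while the three halogens remain indistinguishable from one another. No measurement available here accounts for this shift.

Still open, as far as these compounds go, is whether methoxy, which keeps the oxygen but lacks its hydrogen, or an amine on the same carbon would give a step of the same kind. Also open, from the compounds shown here alone, is whether hydroxy on another carbon of the ring would match the 4-hydroxyphenyl result.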